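Removing the Hydroxy Group from a Weak Phospholipase Inhibitor

The source may hold more compounds than are shown below. What is called first, only, known or untested is meant among the compounds shown, and "the series" means these compounds.

Measured so far:
compound 1, `CCOC(=O)c1nn(-c2ccc(OCC)cc2)cc1O`, 120000 nM
compound 2, `CCCCOC(=O)c1nn(-c2ccc(OCC)cc2)cc1O`, 100000 nM

Both compounds were tested in an assay on isolated protein for inhibition of patatin-like phospholipase domain-containing protein 2 (Mus musculus); on this read-out lower numbers stand for stronger inhibition and higher numbers for weaker inhibition. Compound 1 gives 120000 nM, which is the highest of the two numbers, and compound 2 gives 100000 nM. For the measured compounds named here, the one step that has been measured, a 1.2-fold lower number from compound 1 to compound 2 (0.08 log units; within the scatter), shows that swapping the ester chain makes no difference that stands out from the scatter, so the two compounds are to be read as equally weak.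

Compound 3, `CCOC(=O)c1ccn(-c2ccc(OCC)cc2)n1`, has not yet been measured. It differs from compound 1 in a single place: hydrogen in place of hydroxy on an aromatic carbon. Going by the values given here, no measured step touches this part of the shared core; the only step known, from compound 1 to compound 2, concerns the ester chain and is within the scatter, so it offers no guide to the size or direction of this change. The estimate for compound 3 therefore rests on compound 1 alone and is expected to sit close to it, with a wide range: 200000 nM, between 60000 nM and 600000 nM, meaning a 1.7-fold higher number from compound 1 to compound 3 (0.22 log units; within the scatter) as the expected step.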

Compound 3, half-maximal inhibitory concentration: 40000 nM
Compound 3: middle estimate off by 5.0-fold (0.70 log units), on the high side; the measured number lies below the stated range.
By their numbers in this assay, from the lowest: compound 3; then compounds 2 and 1 (each within the scatter of the next).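

In this assay the hydroxy group on this aromatic carbon proves unnecessary for the weak inhibition seen so far: with hydrogen in its place the read-out shows a 3.0-fold lower number from compound 1 to compound 3 (0.48 log units; beyond the scatter) and this step, though modest, lies beyond the scatter, as the change of ester chain did not. This position is therefore the first place in the series where a single change registers on this read-out, and here the loss of the hydroxy group, with its one hydrogen-bond donor and one acceptor, goes with stronger inhibition rather than weaker. Nothing available explains why the number falls.

The compounds shown compare only hydroxy and hydrogen at this position, so it remains open whether a methoxy group, a fluorine atom or an amine there would lower the number further or raise it again. Also open, going by these compounds, is whether the length of the ester chain matters on the core of compound 3, and whether a carboxylic acid or an amide in place of the ester would keep this gain.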